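This account rests on a few compounds, and the source may have more. Where it says the series, first, only, none or still open, it means among the compounds named here.

Measured in an assay on CHO-K1 cells for displacement of a labelled ligand from prostaglandin E2 receptor EP1 subtype (Homo sapiens), read by scintillation counting, with a stated time of 45 min; a lower number here means a stronger inhibitor, a higher number a weaker inhibitor:
compound 1 `Cc1cc(C(=O)NN2CCOCC2)nn1Cc1cc(Cl)cc2cc(-c3ccccc3)oc12` gives 10 nM
compound 2 `Cc1cc(C(=O)NCC2CCNCC2)nn1Cc1cc(Cl)cc2cc(-c3ccccc3)oc12` gives 20 nM
compound 3 `Cc1cc(NC(=O)CC2CCNCC2)nn1Cc1cc(Cl)cc2cc(-c3ccccc3)oc12` gives 63.1 nM

Compound 3 stands highest of the three in this assay, with a 3.2-fold higher number from compound 2 to compound 3 (0.50 log units; beyond the scatter) and a 6.3-fold higher number from compound 1 to compound 3 (0.80 log units; beyond the scatter), both beyond the scatter. Compound 4 `Cc1cc(C(=O)NC[C@H]2CCCO2)nn1Cc1cc(Cl)cc2cc(-c3ccccc3)oc12` differs from compound 3 by ((oxolan-2-yl)methyl)carbamoyl in place of (((piperidin-4-yl)methyl)carbonyl)amino on an aromatic carbon. For the measured compounds named here, two measured steps bear on this: a 6.3-fold higher number from compound 1 to compound 3 (0.80 log units; beyond the scatter) and a 3.2-fold higher number from compound 2 to compound 3 (0.50 log units; beyond the scatter) each ran from a carbamoyl to the reversed amide and gave a modest rise. Compound 4 restores a carbamoyl, so a modest fall is expected. The choice of amine part appears to matter less, since a 2.0-fold higher number from compound 1 to compound 2 (0.30 log units; within the scatter) stayed within the scatter. The expected step is therefore a 4.2-fold lower number from compound 3 to compound 4 (0.62 log units; beyond the scatter), and compound 4 is estimated at 15 nM, range 5 nM to 50 nM.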

Compound 4, half-maximal inhibitory concentration: 6.31 nM
Compound 4: middle estimate off by 2.4-fold (0.38 log units), on the high side; the range from low to high includes it.
By their numbers in this assay, from the lowest: compounds 4, 1 and 2 (each within the scatter of the next, the first and the last beyond it); then compound 3.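

Restoring the carbamoyl gives a 10-fold lower number from compound 3 to compound 4 (1.00 log units; beyond the scatter) in this assay, but this change also replaces the amine part, so the two contributions cannot be separated. Among the carbamoyl compounds, the amine part now shows an effect: oxolan-2-yl in place of piperidin-4-yl gives a 3.2-fold lower number from compound 2 to compound 4 (0.50 log units; beyond the scatter) on the same chain, while (oxolan-2-yl)methyl in place of morpholin-4-yl gives a 1.6-fold lower number from compound 1 to compound 4 (0.20 log units; within the scatter) and stays within the scatter. No measured evidence accounts for these steps. Open, from the compounds shown here alone, is whether a cyclohexylmethyl or 2-methoxyethyl group on the carbamoyl nitrogen would match the oxolan-2-ylmethyl group. Going by these compounds, the opposite configuration at the oxolane stereocentre also remains open.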